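Trimethoxyphenyl series: chalcone orientation and a methylated arylidene

The source may hold more compounds than are shown below. What is called first, only, known or untested is meant among the compounds shown, and "the series" means these compounds.

Two compounds carry the shared core with a 3,4,5-trimethoxyphenyl group and a phenyl group, and differ only in the orientation of the enone arm. Compound 1 `COc1cc(-c2cc(C(=O)/C=C/c3ccccc3)nc3cc(-c4ccccc4)nn23)cc(OC)c1OC` gives 16300 nM in a functional assay on DU-145 cells (Homo sapiens) for antiproliferative activity, read by MTT assay, with a stated time of 24 h; on this read-out higher numbers stand for weaker inhibition and lower numbers for stronger inhibition. Among the compounds with values here, compound 2 `COc1cc(-c2cc(/C=C/C(=O)c3ccccc3)nc3cc(-c4ccccc4)nn23)cc(OC)c1OC` gives 34300 nM in this assay; this is the higher of the two numbers, and the only measured step, a 2.1-fold higher number from compound 1 to compound 2 (0.32 log units; beyond the scatter), places compound 2 above compound 1 by a margin beyond the scatter.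

Compound 3 `COc1cc(-c2cc(C(=O)/C=C/c3ccc(C)cc3)nc3cc(-c4ccccc4)nn23)cc(OC)c1OC` has not been measured. Relative to compound 2 the change is (2-(4-methylphenyl)ethenyl)carbonyl in place of 2-benzoylethenyl on an aromatic carbon. This restores the enone orientation of compound 1 and adds a methyl-bearing aryl ring in the words of the incoming group. Within the data shown here, the only step that bears on it is the reverse of a 2.1-fold higher number from compound 1 to compound 2 (0.32 log units; beyond the scatter), which was modest but beyond the scatter. Among the measured compounds shown here, a step of similar size in the opposite direction is therefore expected, i.e. a lower number for compound 3 than for compound 2, near the value of compound 1; the methyl has no precedent here, so the range is kept wide. Compound 3 is estimated at 14000 nM (range 5000 nM to 35000 nM) in this assay, an expected step of a 2.5-fold lower number from compound 2 to compound 3 (0.39 log units; beyond the scatter).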

Compound 3, half-maximal inhibitory concentration: 21900 nM
For compound 3 the middle estimate is 1.6-fold (0.19 log units) below the measured one, within the range that was stated.
By their numbers in this assay, from the lowest: compounds 1, 3 and 2 (each within the scatter of the next, the first and the last beyond it).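

In this assay methyl in place of hydrogen on an aromatic carbon of the arm gives a 1.3-fold higher number from compound 1 to compound 3 (0.13 log units; within the scatter) and so leaves no difference that can be told from the scatter at this ring. The other comparison, a 1.6-fold lower number from compound 2 to compound 3 (0.19 log units; within the scatter) as the step, also stays within the scatter, so compound 3 cannot be set apart from either neighbour, even though compound 1 and compound 2 do stand apart from each other and the series shows no clear separation of the two enone orientations once the methyl-bearing ring is involved. No independent data bear on these numbers.

Still open is whether a chlorine, a methoxy group, an amine or a carboxylic acid on the aryl ring of the arm would move the number beyond the scatter, since a single methyl is the only substituent shown there. Also open, from the compounds shown here alone, is whether the enone is needed at all, as a saturated chain or a simple amide in its place would test, and whether the orientation step recurs with 2-(4-methylphenyl) on the reversed arm.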